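The compounds below may be only part of what the source reports. "The series", "measured", "known", "first", "only" and "open" are said of these compounds alone.

Compound 3 `O=c1c(-c2ccc([N+](=O)[O-])cc2)nc2ccccc2n1Cc1ccccc1` gives 1000 nM in an assay on cells for activation of Cystic fibrosis transmembrane conductance regulator (Homo sapiens), read by fluorescence, with a stated time of 10 min; a lower number here means that less compound is needed, a higher number that more compound is needed for the effect. Within the data shown here, that places it level with compound 2 `O=c1c(-c2ccccc2[N+](=O)[O-])nc2ccccc2n1Cc1ccccc1`, which gives 1000 nM, and together these two are the lowest of the three numbers so far, while compound 1 `COC(=O)c1ccc([N+](=O)[O-])c(-c2nc3ccccc3n(Cc3ccccc3)c2=O)c1` gives 9900 nM. Compound 4 `O=c1c(-c2ccccc2)nc2ccccc2n1Cc1ccccc1` differs from compound 3 by hydrogen in place of nitro on an aromatic carbon. Two earlier steps bear on this change. The step of a 9.9-fold lower number from compound 1 to compound 2 (1.00 log units; beyond the scatter) shows that removing a group can move the number markedly. The step of no change at the digits printed from compound 2 to compound 3 (within the scatter) shows that moving the nitro does not. Among the measured compounds shown here, removing the nitro entirely has no direct precedent here, so only a small shift, if any, is expected, and the step to compound 4 is estimated as a 1.5-fold higher number from compound 3 to compound 4 (0.18 log units; within the scatter). Compound 4 is therefore expected near 1500 nM, within 500 nM to 5000 nM.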

Compound 4, half-maximal effective concentration: 5000 nM
The estimate for compound 4 lay 3.3-fold (0.52 log units) below the measured number; the range from low to high includes it.
By their numbers in this assay, from the lowest: compounds 2 and 3 (each within the scatter of the next); then compounds 4 and 1 (each within the scatter of the next).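

In this assay, replacing the nitro with hydrogen gives a 5.0-fold higher number from compound 3 to compound 4 (0.70 log units; beyond the scatter), and the same change from the 2-nitrophenyl compound gives a 5.0-fold higher number from compound 2 to compound 4 (0.70 log units; beyond the scatter). Moving the nitro had left the number unchanged, but these steps show that among these three compounds, having a nitro on this phenyl ring matters more than where it sits. No measurement here explains this difference. On these data alone, it remains open whether the nitro itself is needed: an amine or a carboxylic acid in the same place could give a number like that of compound 3 or one like that of compound 4.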